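The compounds below may be only part of what the source reports. "The series", "measured", "known", "first", "only" and "open" are said of these compounds alone.

Three compounds have numbers in a functional assay on HeLa cells (Homo sapiens) for inhibition, read by cell counting, with a stated time of 4 days; a higher number here means a weaker inhibitor, a lower number a stronger inhibitor. Compound 1 `CCOc1ccc(-c2nn3cc(-c4cccc(N)c4)nc3s2)cc1` gives 94000 nM there. Compound 2 `C=C(Br)C(=O)Nc1cccc(-c2cn3nc(Cc4ccc(Cl)cc4)sc3n2)c1` gives 2700 nM in this assay, the second highest of the three numbers, with compound 3 `C=C(Br)C(=O)Nc1cccc(-c2cn3c(-c4ccc(OC)cc4)csc3n2)c1` nearest at 860 nM in this assay and compound 1 furthest. Compound 4 `C=C(Br)C(=O)Nc1cccc(-c2cn3nc(Cc4ccc(OC)cc4)sc3n2)c1` has not yet been measured. It differs from compound 2 in one place: methoxy in place of chloro on an aromatic carbon. Among the compounds with values here, no measured pair shows this exchange on its own, so the expected step from compound 2 to compound 4 in this assay is judged a small one, a 1.1-fold higher number from compound 2 to compound 4 (0.05 log units; within the scatter), with no firm direction beyond the scatter. On that basis compound 4 is expected to give about 3000 nM in this assay, within a range from 1000 nM to 9000 nM.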

Compound 4, half-maximal inhibitory concentration: 2300 nM
Compound 4: the middle estimate sits 1.3-fold (0.12 log units) above what was measured; measured number inside the range.
By their numbers in this assay, from the lowest: compound 3; then compounds 4 and 2 (each within the scatter of the next); then compound 1.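

In this assay, going from 4-chlorobenzyl to 4-methoxybenzyl gives a 1.2-fold lower number from compound 2 to compound 4 (0.07 log units; within the scatter). Within the data shown here, this is the first single exchange that can be read, and it shows that these two groups at this position cannot be told apart here. No measurement shown bears on why that is.

On these data alone, whether an amine or a carboxylic acid on this same aromatic carbon, or a longer chain such as butoxy in place of methoxy, would move the number beyond the scatter remains open. So does whether the exchange would read the same on the core of compound 3.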